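Adding a Second Fluoro to Compound 2

A few compounds are considered here, and "the series" means these few. Any claim that something is new, unique, unknown or untested is made for them only; others in the source may bear on it.

In a functional assay on CHO cells with adenosine receptor A1 (Homo sapiens) as the target, read by cAMP accumulation and immunoassay, with a stated time of 6 min, tested at 1 uM (on this read-out lower numbers stand for a stronger effect and higher numbers for a weaker effect at the one concentration tested), compound 1 `Nc1scc(CN2CCN(c3ccc(F)cc3Cl)CC2)c1C(=O)c1ccc(Cl)cc1` gives -39%, while compound 2 `Nc1scc(CN2CCN(c3ccccc3F)CC2)c1C(=O)c1ccc(Cl)cc1` gives -9.2%, the higher of the two numbers. Among the compounds with values here, the only step measured so far, a number 29.8 percentage points higher from compound 1 to compound 2 (beyond the scatter), shows that changing the group on the ring amine nitrogen moves this read-out by a modest amount. Compound 3 `Nc1scc(CN2CCN(c3cc(F)ccc3F)CC2)c1C(=O)c1ccc(Cl)cc1` differs from compound 2 by fluoro in place of hydrogen on an aromatic carbon. Within the data shown here, no measured step adds a single fluoro in this way, so only a small shift back toward compound 1 is expected, a number 5.8 percentage points lower from compound 2 to compound 3 (within the scatter). Compound 3 is estimated at -15%, between -35% and 5%.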

Compound 3, a percentage reported as activity, at one concentration (the size of the read-out at that concentration, not a potency): -59%
For compound 3 the middle estimate is 44 percentage points above the measured one; the measured number lies below the stated range.
By their numbers in this assay, from the lowest: compound 3; then compound 1; then compound 2.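

In this assay the change from 2-fluorophenyl to 2,5-difluorophenyl gives a number 49.8 percentage points lower from compound 2 to compound 3 (beyond the scatter) and shows that one fluoro at this ring position, para to the existing fluoro group, can shift the read-out strongly. Replacing 2-chloro-4-fluorophenyl with 2,5-difluorophenyl gives a number 20 percentage points lower from compound 1 to compound 3 (beyond the scatter) so two halogens on this ring do not fix the number.

No measurement here explains the size of the fluoro step. Going by these compounds, whether a methyl or methoxy group at the same position would shift the read-out similarly remains open.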